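The compounds below may be only part of what the source reports. "The series", "measured", "known", "first", "only" and "open" are said of these compounds alone.

Compound 1 `O=c1cc(-n2cc(COc3ccccc3Br)nn2)c2cc(Br)ccc2o1` gives 20100 nM in a functional assay on SW480 cells (Homo sapiens) for antiproliferative activity, read by MTT assay, with a stated time of 48 h; a lower number here means a stronger inhibitor, a higher number a weaker inhibitor. Among the compounds with values here, compound 2 `O=c1cc(-n2cc(COc3ccc(F)cc3)nn2)c2cc(Br)ccc2o1` gives 1770 nM in this assay, and the change an 11-fold lower number from compound 1 to compound 2 (1.06 log units; beyond the scatter) is the only measured step in the set. Compound 2 therefore stands at the lower of the two numbers. Compound 3 `O=c1cc(-n2cc(COc3ccc(F)cc3)nn2)c2ccccc2o1` differs from compound 2 by hydrogen in place of bromo on an aromatic carbon. Within the data shown here, no measured step touches this part of the shared core; the one known step alters the aryl ether instead, so it gives no direct guide. The step of a 1.7-fold higher number from compound 2 to compound 3 (0.23 log units; within the scatter) is what is expected here, within the scatter or slightly weaker. Compound 3 is estimated at 3000 nM, between 800 nM and 12000 nM.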

Compound 3, half-maximal inhibitory concentration: 3820 nM
Estimate against measurement, compound 3: 1.3-fold (0.10 log units) below; the measured number falls inside the stated range.
By their numbers in this assay, from the lowest: compound 2; then compound 3; then compound 1.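

Hydrogen in place of bromo gives a 2.2-fold higher number from compound 2 to compound 3 (0.33 log units; beyond the scatter) in this assay, the first measured change at this place on the shared core. The bromo therefore adds something but is not required for activity, and this step is much smaller than the one on the aryl ether, an 11-fold lower number from compound 1 to compound 2 (1.06 log units; beyond the scatter), so the aryl ether has so far shown the larger change.

From the compounds shown here alone, whether chloro, methoxy or an amine on this aromatic carbon would match bromo remains open, as does whether the step would be the same with the 2-bromophenyl ether. Nothing available explains the difference between bromo and hydrogen.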